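Removing the Ring Hydroxy from a Compound at the Limit

The source may report more compounds than this note shows. Statements on the series, on what has been measured and on what is new or still open speak of the compounds shown alone.

Compound 1 `O=c1[nH]c(=O)n(COC(CO)CO)cc1O` was tested in a functional assay on MIA PaCa-2 cells (Homo sapiens) for inhibition, read by MTT assay, with a stated time of 72 h; on this read-out higher numbers stand for weaker inhibition and lower numbers for stronger inhibition. In this assay compound 1 gives > 100000 nM, which is a limit of the assay and not a measured number. Compound 2 `O=c1nc(NO)cc[nH]1` was tested the same way. In this assay compound 2 gives > 100000 nM, again a limit rather than a number. For the measured compounds named here, compound 1 therefore cannot be placed above or below anything: every value shown sits at the limit of > 100000 nM in this assay, at which 2 of the 2 values shown sit, and no step between two measured compounds exists to be followed.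

Compound 3 `O=c1ccn(COC(CO)CO)c(=O)[nH]1` has not yet been measured in this assay. It differs from compound 1 in one place: hydrogen in place of hydroxy on an aromatic carbon. Going by the values given here, because both measured compounds stop at the limit of > 100000 nM in this assay, at which 2 of the 2 values shown sit, there is no measured step from which the size of this change could be read. The expectation is a step that the limit leaves unreadable from compound 1 to compound 3 in this assay, nothing beyond the usual scatter, with the result most likely staying at the limit. In this assay compound 3 is estimated at 150000 nM, within a range from 50000 nM to 500000 nM.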

Compound 3, half-maximal inhibitory concentration: > 100000 nM
Compound 3: a limit, no number; the forecaster's own chance of this, stated with the estimate: 85%; the middle value lies beyond the limit too.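

Compound 1 and compound 3 both stop at the same limit of the assay, so the exchange of hydroxy for hydrogen yields no step whose size can be read: the limit of > 100000 nM in this assay, at which 3 of the 3 values shown sit.

The compounds shown leave open whether any of them has a real, countable potency in this assay, and whether the hydroxy on the aromatic carbon matters there at all.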